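Swapping an amino acid tail for a diamine tail

A few compounds are considered here, and "the series" means these few. Any claim that something is new, unique, unknown or untested is made for them only; others in the source may bear on it.

Compound 1 `CCCCCCCCCCc1ccc(-c2noc(CCCNC)n2)cc1`: 45%
Compound 2 `CCCCCCCCCCc1ccc(-c2noc(CC3CCNC3)n2)cc1`: 44%
Compound 3 `CCCCCCCCCCc1ccc(-c2noc(CC[C@@H](N)C(=O)O)n2)cc1`: 5%

The three measured compounds share one core and differ only in the group carried on the five-membered ring. In an assay on HeLa cells for inhibition of sphingosine-1-phosphate transporter SPNS2 (Mus musculus), read by LC-MS, tested at 2 uM (a lower number here means less inhibition, a higher number more inhibition at the concentration tested (going by the name of the read-out)), compound 1 and compound 2 sit close together, since a number 1 percentage points lower from compound 1 to compound 2 (within the scatter). Compound 3 stands lowest of the three numbers: a number 40 percentage points lower from compound 1 to compound 3 (beyond the scatter), and likewise a number 39 percentage points lower from compound 2 to compound 3 (beyond the scatter).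

Compound 4 `CCCCCCCCCCc1ccc(-c2noc([C@H](N)CCCCN)n2)cc1` has not yet been measured in this assay. It differs from compound 3 as follows: 1,5-diaminopentyl in place of 3-amino-3-carboxypropyl on an aromatic carbon. The measured steps that bear on this change are the two large drops into compound 3, where groups bearing only an amine were replaced by a group bearing both an amine and a carboxy group. Compound 4 moves in the opposite sense, giving up the carboxy group and carrying two amines, so the expectation is a rise in this assay of roughly the size of those two steps, back toward the level of compound 1 and compound 2. Compound 4 is therefore estimated at 40%, with a range from 20% to 60%. The expected step is a number 35 percentage points higher from compound 3 to compound 4 (beyond the scatter).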

Compound 4, a percentage reported as inhibition, at one concentration (the size of the read-out at that concentration, not a potency): 50%
For compound 4 the middle estimate is 10 percentage points below the measured one; low and high end bracket the measured number.
By their numbers in this assay, from the lowest: compound 3; then compounds 2, 1 and 4 (each within the scatter of the next).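

In this assay, putting 1,5-diaminopentyl in place of 3-amino-3-carboxypropyl on this aromatic carbon gives a number 45 percentage points higher from compound 3 to compound 4 (beyond the scatter), so a tail with no carboxy group can stand at the level of the other amine tails even when its amine-bearing stereocentre is the carbon bound to the ring. The shape of the tail does not separate these compounds: the change from (pyrrolidin-3-yl)methyl gives a number 6 percentage points higher from compound 2 to compound 4 (within the scatter), and the change from 3-(methylamino)propyl gives a number 5 percentage points higher from compound 1 to compound 4 (within the scatter). Of the four compounds, only compound 3, the one with a carboxylic acid, stands apart from the others. Nothing given here explains the size of these steps or the lack of a difference among the amine tails.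

The step into compound 4 removes the carboxylic acid, adds an amine and moves the stereocentre all at once, so the compounds shown cannot assign the rise to any one of these changes. A tail with a single primary amine at the end of the chain, or with a carboxylic acid and no amine, would begin to separate them, and a shorter or longer diamine chain would show how far this level holds.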